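Compound 4 Against a Row of Assay Limits

The source may report more compounds than this note shows. Statements on the series, on what has been measured and on what is new or still open speak of the compounds shown alone.

Compound 1 `C=C[C@@](C)(/C=C/c1ccc(OS(=O)(=O)C(F)(F)F)cc1)CCC=C(C)C` was tested in an ADME assay on BJ cells (Homo sapiens) for cytotoxicity, with a stated time of 72 h; on this read-out lower numbers stand for an effect already at smaller amounts and higher numbers for an effect only at larger amounts of compound. In this assay compound 1 gives > 36600 nM, which is a limit and not a number. Compound 2 `C=C[C@@](C)(/C=C/c1ccc(OS(=O)(=O)c2ccc(C)cc2)cc1)CCC=C(C)C` gives > 36600 nM, also a limit. Compound 3 `C=C[C@](C)(CCCC(C)C)CCc1ccc(O)cc1` gives > 36600 nM, again a limit. Compound 1 therefore has no measured position of its own, and the whole series rests on (the limit of > 36600 nM in this assay, at which 3 of the 3 values shown sit).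

The next compound is compound 4 `C=C[C@@](C)(/C=C/c1ccc(Nc2ccc(Cl)c(F)c2)cc1)CCC=C(C)C`, and the change is (4-chloro-3-fluorophenyl)amino in place of ((trifluoromethyl)sulfonyl)oxy on an aromatic carbon. In words, (4-chloro-3-fluorophenyl)amino replaces ((trifluoromethyl)sulfonyl)oxy on an aromatic carbon. Going by the values given here, only one measured step touches this position: a step that the two limits leave unreadable from compound 1 to compound 2. It has no readable size, so it sets no scale for the new change. Among the compounds with values here, none of the measured compounds carries the entering group, and the data cannot rule out an effect at smaller amounts in this assay.

The expectation is therefore for a modest move towards lower numbers at most, and another limit is quite possible. The estimated change is an at least 1.4-fold lower number from compound 1 to compound 4 (0.16 log units; that floor lies within the scatter). For compound 4 the expected value is 25000 nM, with an estimated range of 8000 nM to 40000 nM.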

Compound 4, half-maximal effective concentration: > 36600 nM
Compound 4: no number, only a limit (the forecaster's own chance of this, stated with the estimate: 55%); middle value at least 1.4-fold (0.16 log units) away from the limit.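

In this assay compound 4 gives > 36600 nM, which is a limit and not a number, so its step from compound 1, also known only as a limit, cannot be read. The series still rests on a single value: the limit of > 36600 nM in this assay, at which 4 of the 4 values shown sit.

The compounds shown leave open at what amount, if any, each would show an effect in this assay.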